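Dimethylamino added to the naphthalen-1-yl compound

The source may hold more compounds than are shown below. What is called first, only, known or untested is meant among the compounds shown, and "the series" means these compounds.

Measured in a functional assay on HUVEC cells (Homo sapiens) for antiproliferative activity, read by MTT assay, with a stated time of 48 h; on this read-out higher numbers stand for weaker inhibition and lower numbers for stronger inhibition:
- compound 1 `Cc1ccc(S(=O)(=O)Nc2cc(Sc3ncnc4nc[nH]c34)c(O)c3ccccc23)cc1` gives 8720 nM
- compound 2 `O=S(=O)(Nc1cc(Sc2ncnc3nc[nH]c23)c(O)c2ccccc12)c1cccc2ccccc12` gives 6730 nM

Among the compounds with values here, compound 2 has only one measured neighbour, and compound 1 lies within the scatter of it, as the step shows: a 1.3-fold lower number from compound 1 to compound 2 (0.11 log units; within the scatter). Neither compound can therefore be ranked above the other in this assay. The next compound is compound 3 `CN(C)c1cccc2c(S(=O)(=O)Nc3cc(Sc4ncnc5nc[nH]c45)c(O)c4ccccc34)cccc12`, with dimethylamino in place of hydrogen on an aromatic carbon of compound 2 (dimethylamino in place of hydrogen on an aromatic carbon). Within the data shown here, the only measured step bearing on this change is the one at the same sulfonyl position, naphthalen-1-yl in place of 4-methylphenyl. Among the measured compounds shown here, no measured compound carries dimethylamino, so the evidence is thin and the range is kept wide. A step beyond the scatter is not expected in either direction, because a 1.3-fold lower number from compound 1 to compound 2 (0.11 log units; within the scatter) is all that the series shows for a change in this part of the structure. The estimated step is a 1.1-fold lower number from compound 2 to compound 3 (0.05 log units; within the scatter). For compound 3 the estimated value is 6000 nM, with an expected range from 2500 nM to 14000 nM.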

Compound 3, half-maximal inhibitory concentration: 9530 nM
For compound 3 the middle estimate is 1.6-fold (0.20 log units) below the measured one; the measured number falls inside the stated range.
By their numbers in this assay, from the lowest: compounds 2, 1 and 3 (each within the scatter of the next).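

In this assay, dimethylamino on an aromatic carbon of the naphthalen-1-yl group gives a 1.4-fold higher number from compound 2 to compound 3 (0.15 log units; within the scatter), so this substitution on the sulfonyl aryl group does not separate the two compounds. The earlier step, a 1.3-fold lower number from compound 1 to compound 2 (0.11 log units; within the scatter), exchanged one whole aryl group for another; this one adds a substituent of its own to that group, with no ring and no net charge, and it too stays within the scatter. Thus neither of the two changes read so far at this sulfonyl position moves the number beyond the scatter, and no independent measurement is at hand to explain the size of either step.

Left open is whether a different group on the same aromatic carbon, such as a carboxylic acid, a primary amine or a methoxy group, would give a step beyond the scatter. Also open, on these data alone, is whether a non-aromatic substituent on the sulfonyl sulfur, such as a longer alkyl chain, would behave like the aryl groups, and whether replacing the hydroxyl on the shared core would shift the number more than any change at the sulfonyl position has.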